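This account rests on a few compounds, and the source may have more. Where it says the series, first, only, none or still open, it means among the compounds named here.

Measured so far:
compound 1 `CCn1c(/C=C2/C(=O)Nc3ccccc32)nc2ccccc21` gives > 50000 nM
compound 2 `CC(C)n1c(/C=C2/C(=O)Nc3ccc(F)cc32)nc2ccccc21` gives 26700 nM
compound 3 `Cn1c(/C=C2/C(=O)Nc3ccc(F)cc32)nc2ccccc21` gives 26900 nM

In a functional assay on BT-549 cells (Homo sapiens) for cytotoxicity, read by MTT assay, with a stated time of 48 h (on this read-out higher numbers stand for weaker inhibition and lower numbers for stronger inhibition), compound 1 gives only a limit, > 50000 nM; this is the limit of > 50000 nM in this assay, at which 1 of the 3 values shown sits, the edge of the measurable range rather than a number. Among the compounds with values here, compound 2 gives 26700 nM in this assay and compound 3 gives 26900 nM; the one step recorded between measured compounds, a 1.0-fold higher number from compound 2 to compound 3 (0.00 log units; within the scatter), is within the scatter, so the size of the alkyl group on the aromatic nitrogen has no visible effect here. Within the data shown here, compound 1 differs from both in two places at once, so no single step connects it to them; what their values show is that the substituted cores of compounds 2 and 3 give numbers where compound 1 gives only a limit.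

Compound 4 `CCn1c(/C=C2/C(=O)Nc3ccc([N+](=O)[O-])cc32)nc2ccccc21` is the next member. It differs from compound 1 by nitro in place of hydrogen on an aromatic carbon. Among the measured compounds shown here, no measured step bears on this exchange: nothing replaces a hydrogen on the core by a nitro group, and nothing in this assay bears on the influence of that ring position beyond the fluoro-bearing compounds 2 and 3, whose numbers sit close to the limit of compound 1. A step from the limit of compound 1 to compound 4 is therefore expected to be an at least 2.0-fold lower number from compound 1 to compound 4 (0.30 log units; that floor lies within the scatter), with a real chance that only a limit is again returned. For compound 4 the estimate in this assay is 25000 nM, between 7000 nM and 60000 nM.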

Compound 4, half-maximal inhibitory concentration: > 50000 nM
Compound 4 gave a limit, no number (the forecaster's own chance of this, stated with the estimate: 40%); middle value at least 2.0-fold (0.30 log units) away from the limit.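

In this assay compound 4 gives > 50000 nM, a limit and not a number. Within the data shown here, compound 1 also gives a limit, so no step between compound 1 and compound 4 can be read: the limit of > 50000 nM in this assay, at which 2 of the 4 values shown sit. The compounds shown leave open whether nitro in place of hydrogen on an aromatic carbon changes the value of the core of compound 1 at all.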